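A few compounds are considered here, and "the series" means these few. Any claim that something is new, unique, unknown or untested is made for them only; others in the source may bear on it.

In a functional assay on CHO cells for agonist activity at Alpha-2C adrenergic receptor (Homo sapiens) (on this read-out higher numbers stand for an effect only at larger amounts of compound and lower numbers for an effect already at smaller amounts), the measured compounds stand as follows:

compound 1 `CSc1ccc(C)cc1NCC1=NCCN1`: 8.91 nM
compound 2 `CS(=O)(=O)c1ccc(F)cc1NCC1=NCCN1`: 2000 nM
compound 3 `Cc1ccc(S(C)(=O)=O)c(NCC2=NCCN2)c1`: 1120 nM

Compound 3 gives the second highest of the three numbers. Against compound 2 the step is small, a 1.8-fold lower number from compound 2 to compound 3 (0.25 log units; within the scatter); against compound 1 it is large, a 130-fold higher number from compound 1 to compound 3 (2.10 log units; beyond the scatter), and that step concerns the methylsulfonyl group, which compound 3 and compound 4 both retain.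

Compound 4 `CS(=O)(=O)c1ccc(C(F)(F)F)cc1NCC1=NCCN1` differs from compound 3 in one place: trifluoromethyl in place of methyl on an aromatic carbon.

Going by the values given here, only one measured step touches this position, a 1.8-fold lower number from compound 2 to compound 3 (0.25 log units; within the scatter), and it lies within the scatter. Nothing measured covers a trifluoromethyl group at any position. On that basis the change from methyl to trifluoromethyl is expected to give no step beyond the scatter in this assay, and the expected step is a 1.3-fold higher number from compound 3 to compound 4 (0.13 log units; within the scatter).

For compound 4 the estimate in this assay is 1500 nM, with a range from 400 nM to 5000 nM.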

Compound 4, half-maximal effective concentration: < 10000 nM
Compound 4: no number, only a limit; the forecaster's own chance of this, stated with the estimate: 10%; the middle value is on the limit's open side.
By their numbers in this assay, from the lowest: compound 1; then compounds 3 and 2 (each within the scatter of the next).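

Compound 4 gives only a limit in this assay, < 10000 nM, so the steps to it from compound 3 and compound 2 cannot be read. The compounds shown leave open whether trifluoromethyl at this position gives a number differing beyond the scatter from those with methyl or fluoro.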